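The compounds below may be only part of what the source reports. "The series", "measured", "known", "first", "only" and "open" are said of these compounds alone.

Three compounds have been measured in a functional assay on CHO-K1 cells for antagonist activity at transient receptor potential cation channel subfamily V member 1 (Homo sapiens), read by FLIPR; a higher number here means a weaker inhibitor, a lower number a stronger inhibitor:

- compound 1, `CC(C(=O)NCc1ccc(C(F)(F)F)nc1NC1CCCCC1)c1ccc(NS(C)(=O)=O)c(F)c1`: 20.4 nM
- compound 2, `CC(C(=O)NCc1ccc(C(F)(F)F)nc1NCc1ccccc1)c1ccc(NS(C)(=O)=O)c(F)c1`: 15.8 nM
- compound 3, `CC(C(=O)NCc1ccc(C(F)(F)F)nc1NCc1ccc(Cl)cc1)c1ccc(NS(C)(=O)=O)c(F)c1`: 65.7 nM

Compound 1 has the second highest of the three numbers. Its nearest neighbour is compound 2, with a 1.3-fold lower number from compound 1 to compound 2 (0.11 log units; within the scatter), a gap that cannot be told from repeat measurement noise. The furthest is compound 3, with a 3.2-fold higher number from compound 1 to compound 3 (0.51 log units; beyond the scatter). Between the two benzyl compounds the change is a 4.2-fold higher number from compound 2 to compound 3 (0.62 log units; beyond the scatter).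

Compound 4, `CC(C(=O)NCc1ccc(C(F)(F)F)nc1N(C)c1ccccc1)c1ccc(NS(C)(=O)=O)c(F)c1`, is not yet measured. Compared with compound 1 the change is methyl(phenyl)amino in place of cyclohexylamino on an aromatic carbon. Within the data shown here, no measured step removes the hydrogen-bond donor at this position or places the aromatic ring directly on the nitrogen, so the closest guide is a 1.3-fold lower number from compound 1 to compound 2 (0.11 log units; within the scatter), which shows that swapping a saturated ring for an aromatic one here leaves the number essentially unchanged; a 4.2-fold higher number from compound 2 to compound 3 (0.62 log units; beyond the scatter) shows that further additions to that ring can cost activity modestly. On this basis the expectation for compound 4 is a number near that of compound 1, possibly somewhat higher, in this assay. The estimated value for compound 4 is 40 nM, with a range from 12 nM to 150 nM. This estimate corresponds to an expected step of a 2.0-fold higher number from compound 1 to compound 4 (0.29 log units; within the scatter).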

Compound 4, inhibition constant: 0.9 nM
Compound 4: middle estimate off by 44-fold (1.65 log units), on the high side; the measured number lies below the stated range.
By their numbers in this assay, from the lowest: compound 4; then compounds 2 and 1 (each within the scatter of the next); then compound 3.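

Before compound 4, changes to the group on this aromatic carbon next to the ring nitrogen had moved the number in this assay only modestly or within the scatter, but methyl(phenyl)amino gives a 23-fold lower number from compound 1 to compound 4 (1.36 log units; beyond the scatter), an 18-fold lower number from compound 2 to compound 4 (1.24 log units; beyond the scatter) and a 73-fold lower number from compound 3 to compound 4 (1.86 log units; beyond the scatter). This position can therefore shift the number far more than the cyclohexylamino and benzylamino compounds showed, and the largest shift here comes with a group that has 0 hydrogen-bond donors where the groups in compounds 1, 2 and 3 each have 1. Nothing available explains the size of this shift.

The new group brings the methyl and the directly attached phenyl ring together, so the compounds shown cannot say which of the two carries the shift; phenylamino and methyl(cyclohexyl)amino at this position would pull them apart. Also open, as far as these compounds go, is whether a chloro on the phenyl ring of compound 4 would cost activity as it did in a 4.2-fold higher number from compound 2 to compound 3 (0.62 log units; beyond the scatter), or whether an ethyl in place of the methyl would keep the low number.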